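The compounds below may be only part of what the source reports. "The series", "measured", "known", "first", "only" and "open" are said of these compounds alone.

In an assay on isolated protein for binding affinity to corticotropin-releasing factor receptor 1 (Rattus norvegicus) (on this read-out lower numbers stand for stronger inhibition and higher numbers for weaker inhibition), compound 1 `CCCCN(CC)c1cc(C)nc2c1NC(=O)CN2c1ccc(OC)nc1OC` gives 0.82 nM. Compound 2 `CCN(CCCC#N)c1cc(C)nc2c1NC(=O)CN2c1ccc(OC)cc1C` gives 92 nM in this assay, the higher of the two numbers, and its gap to compound 1 lies well beyond the scatter. Compound 3 `CCCCN(CC)c1cc(C)nc2c1NC(=O)CN2c1ccc(OC)cc1C` has not been measured; it differs from compound 2 by methyl in place of cyano on a saturated chain carbon, three bonds along the chain from a nitrogen on an aromatic ring. Within the data shown here, no measured pair isolates this change, and compound 1 differs from compound 3 in another place as well. The step from compound 2 to compound 3 is nonetheless expected to be a fall of a 9.2-fold lower number from compound 2 to compound 3 (0.96 log units; beyond the scatter), because compound 1 gives 0.82 nM with the same butyl and ethyl chains. Compound 3 is estimated at 10 nM, within 1.5 nM to 70 nM.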

Compound 3, half-maximal inhibitory concentration: 0.92 nM
For compound 3 the middle estimate is 11-fold (1.04 log units) above the measured one, and the stated range ends above it.
By their numbers in this assay, from the lowest: compounds 1 and 3 (each within the scatter of the next); then compound 2.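

In this assay, methyl in place of cyano, which turns the 3-cyanopropyl chain into butyl, gives a 100-fold lower number from compound 2 to compound 3 (2.00 log units; beyond the scatter). Compound 2 and compound 3 differ in this one place only, so this large step belongs to that single change on the chain, with the rest of the molecule unchanged. The compounds shown leave open how other chain ends at this place would compare, such as a hydroxyl group, an amine or a shorter propyl chain. No measurement here explains why this change has so large an effect.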